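This account rests on a few compounds, and the source may have more. Where it says the series, first, only, none or still open, it means among the compounds named here.

Measured so far:
compound 1 `O=C(Nc1cccc(Oc2nccc(C(F)(F)F)c2Cl)c1)C1CCCN(C(=O)c2cc(C(F)(F)F)cc(C(F)(F)F)c2)C1` — 0%
compound 2 `C=Cc1cccc(C(=O)N2CCCC(C(=O)Nc3ccc(Cl)cc3)C2)c1` — 0%

In an ADME assay on PC-3 cells (Homo sapiens) for cytotoxicity, read by WST assay, tested at 100 uM (a lower number here means less inhibition, a higher number more inhibition at the concentration tested (going by the name of the read-out)), compound 1 gives 0% and compound 2 gives 0%. Compound 2 thus stands level with compound 1 at the digits shown, and the two values lie within the usual scatter of each other, so nothing can be said about one being higher or lower than the other. Both sit at the floor of the read-out: at the concentration tested, neither compound lowers the signal from the cells.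

Compound 3 `Cc1nc(-c2cccc(C(=O)N3CCCC(C(=O)Nc4ccc(Cl)cc4)C3)c2)cs1` has not been measured. It differs from compound 2 in one place: 2-methyl-1,3-thiazol-4-yl in place of vinyl on an aromatic carbon. Among the measured compounds shown here, no pair of measured compounds that differ in one place is available, so there is no earlier step to show how such a swap has moved this read-out. Since compound 2 gives 0% and compound 1, with quite different groups, sits at the same level, the step expected in this assay is a number 3 percentage points higher from compound 2 to compound 3 (within the scatter), which is none beyond the scatter. Compound 3 is therefore estimated at 3%, with a range from -8% to 15%.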

Compound 3, a percentage reported as inhibition, at one concentration (the size of the read-out at that concentration, not a potency): 1%
The estimate for compound 3 lay 2 percentage points above the measured number; low and high end bracket the measured number.
By their numbers in this assay, from the lowest: compounds 1, 2 and 3 (each within the scatter of the next).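

In this assay, placing 2-methyl-1,3-thiazol-4-yl in place of vinyl on an aromatic carbon of a six-membered aromatic ring of carbon only, meta to a large group, gives a number 1 percentage points higher from compound 2 to compound 3 (within the scatter). Among the compounds shown here, this is the first change in a single place that can be read here, and it shows that this position can carry a group of 6 heavy atoms, with one five-membered aromatic ring and 2 hydrogen-bond acceptors, instead of a vinyl of 2 heavy atoms, without the number moving beyond the scatter, something the comparison of compound 1 with compound 2 could not show, as those two differ in more than one place. No measurement on hand offers an explanation for this flat result.

From the compounds shown here alone, it remains open whether a group of another kind at this same position, such as an amine, a carboxylic acid or a longer chain, would also leave the number within the scatter of compound 2. Also open, going by these compounds, is whether a change in a different part of the shared core would lift the read-out clear of the scatter at all.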